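Carbamate ester variation on the shared core

A few compounds are considered here, and "the series" means these few. Any claim that something is new, unique, unknown or untested is made for them only; others in the source may bear on it.

Measured so far in a functional assay on CHO-K1 cells with Glucose-dependent insulinotropic receptor (Homo sapiens) as the target, read by a luciferase reporter, with a stated time of 5 h; on this read-out higher numbers stand for larger maximal responses and lower numbers for smaller maximal responses:
compound 1 `CC(C)OC(=O)N1CCC(Oc2ncnc3c2CCN3c2ccc(S(C)(=O)=O)cc2F)CC1` — 91%
compound 2 `CC(C)OC(=O)N1CCC(Oc2ncnc3c2CCN3c2ccc(S(C)(=O)=O)cc2)CC1` — 154%
compound 3 `CC(C)OC(=O)N1CCC(Oc2ncnc3c2CCN3c2ccc(-c3cccn3C)cc2F)CC1` — 44%

Compound 1 holds the second highest of the three values. Its nearest neighbour is reached by the step of a number 47 percentage points lower from compound 1 to compound 3 (beyond the scatter); the furthest by the step of a number 63 percentage points higher from compound 1 to compound 2 (beyond the scatter). Both measured steps change the substituent on the aryl ring that carries the core nitrogen, and both are large.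

Compound 4 `COC(=O)N1CCC(Oc2ncnc3c2CCN3c2ccc(S(C)(=O)=O)cc2F)CC1` differs from compound 1 at a different place: methyl in place of isopropyl on an oxygen next to a carbonyl group. Among the measured compounds shown here, neither measured step touches this carbamate, so no measured step bears on the change; what is known of the series leaves it open. The working expectation for compound 4 is therefore a step of a number 3 percentage points lower from compound 1 to compound 4 (within the scatter), within the scatter, with a widened range. Compound 4 is estimated at 88%, between 55% and 125%.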

Compound 4, largest response reached (reported as percent of maximum), in percent of the reference or control that the assay uses: 119%
Beside the measured number, compound 4's estimate is 31 percentage points below it, within the range that was stated.
By their numbers in this assay, from the lowest: compound 3; then compound 1; then compound 4; then compound 2.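

The carbamate ester is not a silent position: methyl in place of isopropyl on an oxygen next to a carbonyl group gives the step of a number 28 percentage points higher from compound 1 to compound 4 (beyond the scatter) in this assay. The isopropyl group is therefore not required for the maximal response of this aryl-substituted compound, and a change away from the aryl ring also moves the read-out. Nothing available explains this rise.

From the compounds shown here alone, whether an ethyl or tert-butyl ester would continue in the same direction remains open. Going by these compounds, it is also open whether the methyl change would have a similar effect on compound 2, which lacks the fluoro group.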